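This account rests on a few compounds, and the source may have more. Where it says the series, first, only, none or still open, it means among the compounds named here.

Working notes on the series. Compound 1 `CN1CCN(c2ccc(C3=NN(S(C)(=O)=O)C(c4ccc(N(C)C)cc4)C3)cc2)CC1` and compound 3 `CN(C)c1ccc(C2CC(c3ccc(-n4cncn4)cc3)=NN2S(C)(=O)=O)cc1` share a core that differs only in 1H-1,2,4-triazol-1-yl in place of 4-methylpiperazin-1-yl on an aromatic carbon. In a functional assay on NCI-H1975 cells (Homo sapiens) for inhibition, read by sulforhodamine B assay, tested at 10 uM (on this read-out higher numbers stand for more inhibition at the one concentration tested (going by the name of the read-out) and lower numbers for less inhibition), compound 1 gives -1.3%, and compound 3 gives -3.1%; the step of a number 1.8 percentage points lower from compound 1 to compound 3 (within the scatter) lies within the scatter. Compound 2 `Cc1ccc(S(=O)(=O)N2N=C(c3ccc(N4CCN(C)CC4)cc3)CC2c2ccc(N(C)C)cc2)cc1` differs from compound 1 by 4-methylphenyl in place of methyl on a sulfonyl sulfur, and in this assay compound 2 gives 38.1%, a step of a number 39.4 percentage points higher from compound 1 to compound 2 (beyond the scatter). Compound 4 `Cc1ccc(S(=O)(=O)N2N=C(c3ccc(-n4cncn4)cc3)CC2c2ccc(N(C)C)cc2)cc1`, not yet measured, carries the same change relative to compound 3: 4-methylphenyl in place of methyl on a sulfonyl sulfur, at a place described in the same words. Because compound 3 sits at -3.1%, close to compound 1, a step of similar size is expected here, estimated as a number 38.1 percentage points higher from compound 3 to compound 4 (beyond the scatter). For the measured compounds named here, compound 4 is thus expected to give about 35% in this assay, between 15% and 55%, resting on the single comparable step.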

Compound 4, a percentage reported as inhibition, at one concentration (the size of the read-out at that concentration, not a potency): 20%
Compound 4: the middle estimate sits 15 percentage points above what was measured, within the range that was stated.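

In this assay, 4-methylphenyl in place of methyl on a sulfonyl sulfur gives a number 23.1 percentage points higher from compound 3 to compound 4 (beyond the scatter), so the direction of the step carries over to the second core, but its size does not: the same change on two cores in this assay, a number 39.4 percentage points higher (beyond the scatter) from compound 1 to compound 2 and a number 23.1 percentage points higher (beyond the scatter) from compound 3 to compound 4, 16.3 percentage points apart, beyond the scatter of two such steps

1H-1,2,4-triazol-1-yl in place of 4-methylpiperazin-1-yl gives a number 18.1 percentage points lower from compound 2 to compound 4 (beyond the scatter), so this change is beyond the scatter only with 4-methylphenyl on the sulfonyl sulfur: the same change on two cores in this assay, a number 1.8 percentage points lower (within the scatter) from compound 1 to compound 3 and a number 18.1 percentage points lower (beyond the scatter) from compound 2 to compound 4, 16.3 percentage points apart, beyond the scatter of two such steps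

These two pairs show that the two changes do not add independently here, but they do not show why, or how either step would behave on a further core.

Open, as far as these compounds go, is whether a longer alkyl chain or an unsubstituted phenyl on the sulfonyl sulfur follows the same direction. Also open, from the compounds shown here alone, is how a carboxylic acid or an amine in place of 4-methylpiperazin-1-yl would read.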